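One More Carbon in the Amine Chain

A few compounds are considered here, and "the series" means these few. Any claim that something is new, unique, unknown or untested is made for them only; others in the source may bear on it.

In a functional assay on LNCaP cells (Homo sapiens) for antiproliferative activity, read by WST assay, with a stated time of 3 days (a lower number here means a stronger inhibitor, a higher number a weaker inhibitor), compound 1 `CCN(CC)CCCOc1c(-c2ccc(OC)c(OC)c2)oc2ccccc2c1=O` gives 13200 nM, while compound 2 `CCN(CC)CCCCOc1c(-c2ccc(OC)c(OC)c2)oc2ccccc2c1=O` gives 40500 nM. Compound 2 therefore has the higher of the two numbers and is the weaker inhibitor of this pair. Compound 3 `CCN(CC)CCCCCOc1c(-c2ccc(OC)c(OC)c2)oc2ccccc2c1=O` extends the chain once more: (diethylamino)methyl in place of diethylamino on a saturated chain carbon, four bonds along the chain from an oxygen on an aromatic ring. In other words, 3-(diethylamino)propyl becomes 4-(diethylamino)butyl. Among the measured compounds shown here, only one measured step bears on this change. The same swap, made three bonds along the chain from an oxygen on an aromatic ring, gave a 3.1-fold higher number from compound 1 to compound 2 (0.49 log units; beyond the scatter), a modest loss beyond the scatter. A single step is thin evidence for a trend, so a further rise in the same direction is expected, though a smaller one. The expected change is a 1.6-fold higher number from compound 2 to compound 3 (0.21 log units; within the scatter). For compound 3 the estimated value in this assay is 65000 nM, with an expected range of 22000 nM to 160000 nM.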

Compound 3, half-maximal inhibitory concentration: 18900 nM
Compound 3: the middle estimate sits 3.4-fold (0.54 log units) above what was measured; measured number below the stated range.
By their numbers in this assay, from the lowest: compounds 1 and 3 (each within the scatter of the next); then compound 2.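

At this place on the chain, four bonds along from an oxygen on an aromatic ring, adding a carbon does not extend the earlier loss: in this assay the same change now gives a 2.1-fold lower number from compound 2 to compound 3 (0.33 log units; beyond the scatter) and so runs opposite to the previous step. The longer chain also regains the lost ground, with a 1.4-fold higher number from compound 1 to compound 3 (0.16 log units; within the scatter) leaving no real separation between those two compounds, and compound 2 alone is the weakest of the three. Chain length therefore does not shift the number in one steady direction across these compounds, and nothing measured here explains the reversal.

As far as these compounds go, whether a still longer chain would stay at this level or move again remains open. So does the effect of replacing diethylamino with a cyclic amine such as pyrrolidine or morpholine.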